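Pyridine in Place of Phenyl on the Tetrazole Arm

The source may hold more compounds than are shown below. What is called first, only, known or untested is meant among the compounds shown, and "the series" means these compounds.

Compound 3 `Cc1cc(NC(=O)Cn2nnc(-c3ccc(F)cc3)n2)n(C2CCCCC2)n1` gives 92% in an assay on HEK293 cells for activation of Kir3.1/Kir3.2 (Homo sapiens), read by thallium flux (on this read-out higher numbers stand for larger maximal responses and lower numbers for smaller maximal responses), and stands level with compound 1 `Cc1cc(NC(=O)Cn2nnc(-c3ccccc3)n2)n(C2CCCCC2)n1`, which gives 92%. Compound 2 `Cc1cc(NC(=O)Cn2nnc(-c3cccc(Cl)c3)n2)n(C2CCCCC2)n1` gives 89%; the step of a number 3 percentage points higher from compound 2 to compound 3 (within the scatter) lies within the scatter. Compound 4 `Cc1cc(NC(=O)Cn2nnc(-c3ccnc(F)c3)n2)n(C2CCCCC2)n1` differs from compound 3 by 2-fluoropyridin-4-yl in place of 4-fluorophenyl on an aromatic carbon. The measured steps that bear on this all change the ring on the tetrazole: a number 3 percentage points lower from compound 1 to compound 2 (within the scatter) and no change at the digits printed from compound 1 to compound 3 (within the scatter). None of them exchanges a ring carbon for a ring nitrogen, so they speak only indirectly, but they show the maximal response tolerant of change at this ring. Compound 4 is therefore expected to give 86%, between 62% and 100%, the estimated step of a number 6 percentage points lower from compound 3 to compound 4 (within the scatter) lying within the scatter.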

Compound 4, largest response reached (Emax), in percent of the reference or control that the assay uses: 95%
Compound 4: middle estimate off by 9 percentage points, on the low side; low and high end bracket the measured number.
By their numbers in this assay, from the lowest: compounds 2, 1, 3 and 4 (each within the scatter of the next).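

In this assay, among the compounds shown here, the exchange of a ring carbon for a ring nitrogen, which no earlier step contained, can now be read directly, with 2-fluoropyridin-4-yl in place of 4-fluorophenyl giving a number 3 percentage points higher from compound 3 to compound 4 (within the scatter). The other two comparisons with the new group give a number 3 percentage points higher from compound 1 to compound 4 (within the scatter) and a number 6 percentage points higher from compound 2 to compound 4 (within the scatter), so all the ring changes shown at this position remain within the scatter. The data shown offer no explanation for this result.

On these data alone, whether pyridin-3-yl or unsubstituted pyridin-4-yl would give the same response remains open. So does the effect of an amine or a carboxylic acid on this ring.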